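A few compounds are considered here, and "the series" means these few. Any claim that something is new, unique, unknown or untested is made for them only; others in the source may bear on it.

In a functional assay on A549 cells (Homo sapiens) for cytotoxicity, read by MTT assay, with a stated time of 72 h (a lower number here means a stronger inhibitor, a higher number a weaker inhibitor), compound 1 `CCOC(=O)c1c(C)oc2ncnc(Nc3ccccc3)c12` gives > 1000000 nM as its reading, which is a limit of the assay and not a number. Among the measured compounds shown here, compound 2 `Cc1cccc(Nc2ncnc3oc(C)c(C(=O)O)c23)c1` gives 100000 nM as the only true number so far, with no other number to rank it against. Compound 3 `Cc1oc2ncnc(Nc3ccccc3)c2c1C(=O)O` is still to be measured and departs from compound 2 by hydrogen in place of methyl on an aromatic carbon in one place, with hydrogen in place of methyl on an aromatic carbon, meta to a large group, so that 3-methylphenyl becomes phenyl. For the measured compounds named here, no measured pair isolates this change, so the expectation rests on compound 2 at 100000 nM alone. In this assay the expected 1.5-fold higher number from compound 2 to compound 3 (0.18 log units; within the scatter) is small, leaning slightly toward a weaker inhibitor, and not beyond the usual scatter. Compound 3 is estimated at 150000 nM with an expected range from 50000 nM to 500000 nM for now.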

Compound 3, half-maximal inhibitory concentration: 191000 nM
The estimate for compound 3 lay 1.3-fold (0.10 log units) below the measured number; measured number inside the range.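

In this assay, hydrogen in place of methyl on an aromatic carbon, meta to a large group, reads a 1.9-fold higher number from compound 2 to compound 3 (0.28 log units; within the scatter), so the 3-methylphenyl and phenyl acids cannot be told apart at this position. Among the compounds shown here, with phenyl held constant, hydrogen in place of ethyl on an oxygen next to a carbonyl group reads an at least 5.2-fold lower number from compound 1 to compound 3 (0.71 log units; beyond the scatter), the first step beyond the scatter. Compound 1 reads as a limit of the assay and not a number, and the full size of that step stays unknown because of this limit: the limit of > 1000000 nM in this assay, at which 1 of the 3 values shown sits.

As far as these compounds go, whether a larger group at the same place, such as methoxy or chlorine, would separate from methyl and hydrogen remains open. So does whether a primary amide in place of the carboxylic acid would read like compound 3 or like compound 1.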